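Carboxy on the phenyl ring across two related cores

This account rests on a few compounds, and the source may have more. Where it says the series, first, only, none or still open, it means among the compounds named here.

Measured compounds in a functional assay on the whole organism with Rattus norvegicus as the target; a lower number here means that less compound is needed, a higher number that more compound is needed for the effect:
compound 1, `CC1CCC(=NNc2ccccc2)c2ncc(C(=O)O)c(=O)n21`: compound 1 gives 1.2 umol/kg.
compound 2, `CC1CCC(=NNc2ccccc2C(=O)O)c2ncc(C(=O)O)c(=O)n21`: for compound 2 this assay reports only a limit, > 100 umol/kg.
compound 3, `CC1CCC(N=Nc2ccccc2)=C2N(C)C=C(C(=O)O)C(=O)N21`: for compound 3 this assay reports only a limit, > 100 umol/kg.

Compound 1 and compound 2 share a core and differ in one place: carboxy in place of hydrogen on an aromatic carbon. This change produced an at least 83-fold higher number from compound 1 to compound 2 (1.92 log units; beyond the scatter), so the carboxy on the phenyl ring is tied to a large loss in this assay. Compound 3 carries a different core; the difference between the two cores is not broken down here, and compound 3 itself sits at the limit of this assay.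

Compound 4, `CC1CCC(N=Nc2ccccc2C(=O)O)=C2N(C)C=C(C(=O)O)C(=O)N21`, is not yet measured. It stands to compound 3 as compound 2 stands to compound 1: carboxy in place of hydrogen on an aromatic carbon. The place is described in the same words for both pairs, with the further note that in compound 4 the change reads phenyl to 2-carboxyphenyl when cut one bond further out, so this is the same kind of change made on the other core.

The expectation for compound 4 in this assay is a step that the limit leaves unreadable from compound 3 to compound 4, which rests on compound 3 already being at the limit and on the earlier pair, where the carboxy brought an at least 83-fold higher number from compound 1 to compound 2 (1.92 log units; beyond the scatter). Compound 4 is estimated at 300 umol/kg, with a range from 100 umol/kg to 1000 umol/kg, and because of the limit of > 100 umol/kg in this assay, at which 2 of the 3 values shown sit, a limit rather than a number is the expected outcome.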

Compound 4, dose for 50% inhibition: > 100 umol/kg
Compound 4: no number, only a limit; the forecaster's own chance of this, stated with the estimate: 90%; the middle value is on the limit's open side.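

In this assay compound 4 gives > 100 umol/kg, a limit and not a number. For the compounds shown here, compound 3 also gives only a limit, > 100 umol/kg, so no step from compound 3 to compound 4 can be read. The compounds shown leave open whether the change from phenyl to 2-carboxyphenyl has any effect on the core of compound 3, as it does on the core of compound 1.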